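The source may hold more compounds than are shown below. What is called first, only, known or untested is meant among the compounds shown, and "the series" means these compounds.

Among the compounds with values here, in an ADME assay on MT4 cells (Homo sapiens) for cytotoxicity, read by MTT assay, with a stated time of 4 days (on this read-out lower numbers stand for higher toxicity in this test and higher numbers for lower toxicity in this test), only two compounds have numbers so far. Compound 1 (`Cc1c(Cc2c(F)cccc2F)nc(N(C)C(C)C)[nH]c1=O`) gives 79000 nM and compound 2 (`CCN(C)c1nc(C(C)c2c(F)cccc2F)c(C)c(=O)[nH]1`) gives 81000 nM in this test, so the two lie within the usual scatter of repeated measurements and compound 2 stands level with compound 1. Compound 3 (`Cc1c(C(C)c2c(F)cccc2F)nc(N(C)C(C)C)[nH]c1=O`) is still unmeasured. It differs from compound 2 by a single change (methyl in place of hydrogen on a saturated chain carbon bound to a nitrogen on an aromatic ring and a saturated chain carbon): methyl in place of hydrogen on a saturated chain carbon bound to a nitrogen on an aromatic ring and a saturated chain carbon, which turns ethyl(methyl)amino into isopropyl(methyl)amino. Within the data shown here, no measured pair shows this change on its own, so the starting point is compound 2 at 81000 nM and no step beyond the scatter is expected in this assay here. The expected size is a 1.1-fold lower number from compound 2 to compound 3 (0.03 log units; within the scatter) and that stays within the scatter. For compound 3 the estimated value is 75000 nM (expected range 35000 nM to 160000 nM).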

Compound 3, half-maximal cytotoxic concentration: > 81000 nM
Compound 3: only a limit was reported (the forecaster's own chance of this, stated with the estimate: 15%); middle value at least 1.0-fold (0.03 log units) away from the limit.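

In this assay the reading for compound 3 is a limit of the assay and not a number: the limit of > 81000 nM in this assay, at which 1 of the 3 values shown sits. Methyl in place of hydrogen on a saturated chain carbon bound to a nitrogen on an aromatic ring and a saturated chain carbon gives a number no lower from compound 2 to compound 3 (the limit leaves the size open). Methyl in place of hydrogen on a saturated chain carbon bound to two aromatic carbons gives an at least 1.0-fold higher number from compound 1 to compound 3 (0.01 log units; that floor lies within the scatter) and so, at both places, this small addition brings no lower number in this test.

On these data alone, how far the true value of compound 3 lies past the limit stays open. So does whether a larger group at either place, such as a cyclopropyl or a longer chain, would also leave the number this high.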